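Replacing 2,4,5-trichlorophenyl with 3-chlorophenyl in the propyl compounds

The source may report more compounds than this note shows. Statements on the series, on what has been measured and on what is new or still open speak of the compounds shown alone.

Among the measured compounds shown here, in a functional assay on MCF7 cells (Homo sapiens) for antiproliferative activity, read by sulforhodamine B assay, with a stated time of 48 h (a higher number here means a weaker inhibitor, a lower number a stronger inhibitor), compound 3 (`CCCN1CCN(c2ccc(S(=O)(=O)Oc3cc(Cl)c(Cl)cc3Cl)cc2)C1=O`) gives 13000 nM, the highest of the three numbers so far, which makes it the weakest inhibitor measured. Compound 1 (`CCN1CCN(c2ccc(S(=O)(=O)Oc3cccc(Cl)c3)cc2)C1=O`) gives 5400 nM, and compound 2 (`CCCN1CCN(c2ccc(S(=O)(=O)Oc3ccc(C)cc3C)cc2)C1=O`) gives 1500 nM.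

Compound 4 (`CCCN1CCN(c2ccc(S(=O)(=O)Oc3cccc(Cl)c3)cc2)C1=O`) has not been measured. It keeps the propyl chain of compound 3 and differs in one place, on an oxygen bound to the sulfonyl sulfur: 3-chlorophenyl in place of 2,4,5-trichlorophenyl on an oxygen.

For the measured compounds named here, one measured step bears directly on this change: an 8.7-fold higher number from compound 2 to compound 3 (0.94 log units; beyond the scatter). It is a modest step at the same oxygen with propyl retained, and it shows that the number can move beyond the scatter with the group there. However, it involves 2,4-dimethylphenyl rather than 3-chlorophenyl. Going by the values given here, compound 1 carries the entering 3-chlorophenyl, but with ethyl in place of propyl, and its 5400 nM is therefore only a guide, since no measured step isolates the chain difference.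

A somewhat smaller step than the measured one is expected, towards a lower number and beyond the scatter: a 3.3-fold lower number from compound 3 to compound 4 (0.51 log units; beyond the scatter). Compound 4 is estimated at 4000 nM, with an expected range of 1500 nM to 10000 nM.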

Compound 4, half-maximal inhibitory concentration: 380 nM
The estimate for compound 4 lay 11-fold (1.02 log units) above the measured number; the whole stated range lies above it.
By their numbers in this assay, from the lowest: compound 4; then compound 2; then compound 1; then compound 3.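

In this assay the group on an oxygen bound to the sulfonyl sulfur moves the number much further than the earlier propyl pair showed: a 34-fold lower number from compound 3 to compound 4 (1.53 log units; beyond the scatter) is a large step, and a 3.9-fold lower number from compound 2 to compound 4 (0.60 log units; beyond the scatter) places 3-chlorophenyl ahead of 2,4-dimethylphenyl as well, so it gives the lowest number of the three groups compared on the propyl chain. Among the compounds shown here, the chain also matters, which no earlier pair could show: with 3-chlorophenyl held constant, the change from ethyl to propyl gives a 14-fold lower number from compound 1 to compound 4 (1.15 log units; beyond the scatter) and is also large. No measurement on hand accounts for either effect.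

As far as these compounds go, whether propyl gives a similar drop with 2,4-dimethylphenyl or 2,4,5-trichlorophenyl on the oxygen remains open, as does whether a longer chain such as butyl lowers the number further. Also open, from the compounds shown here alone, is how this assay would read with a methoxy or nitrile group on the phenyl ring, or with an amine at the end of the chain.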